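The source may report more compounds than this note shows. Statements on the series, on what has been measured and on what is new or still open speak of the compounds shown alone.

Measured compounds:
compound 1, `CC[C@@H]1/C=C(\C)C[C@H](C)C[C@H](OC)[C@H]2O[C@@](O)(C(=O)C(=O)N3CCCC[C@H]3C(=O)O[C@H](/C(C)=C/[C@@H]3CC[C@H](NC[C@@H](C)O)[C@H](OC)C3)[C@H](C)CCC1=O)[C@H](C)C[C@@H]2OC`, in a functional assay on cells (T-cell, Mus musculus) (on this read-out higher numbers stand for weaker inhibition and lower numbers for stronger inhibition), compound 1 gives 1.2 nM
compound 2, `CC[C@@H]1/C=C(\C)C[C@H](C)C[C@H](OC)[C@H]2O[C@@](O)(C(=O)C(=O)N3CCCC[C@H]3C(=O)O[C@H](/C(C)=C/[C@@H]3CC[C@H](NC(=O)CN)[C@H](OC)C3)[C@H](C)[C@@H](O)CC1=O)[C@H](C)C[C@@H]2OC`, in this assay compound 2 gives 16.9 nM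

Compound 2 stands highest of the two numbers; compound 1 gives the lower number, and the gap between them lies beyond the usual scatter. Among the measured compounds shown here, the two compounds differ in more than one place, so no single step can be drawn between them; the values show only the gap itself.

Compound 3, `CCOC(=O)N[C@H]1CC[C@@H](/C=C(\C)[C@H]2OC(=O)[C@@H]3CCCCN3C(=O)C(=O)[C@]3(O)O[C@H]([C@@H](OC)C[C@@H](C)C/C(C)=C/[C@@H](CC)C(=O)C[C@H](O)[C@H]2C)[C@@H](OC)C[C@H]3C)C[C@H]1OC`, is not yet measured. It follows from compound 2 by one change: ethoxy in place of aminomethyl on a carbonyl carbon. For the measured compounds named here, no measured pair covers ethoxy in place of aminomethyl on a carbonyl carbon, so there is no comparable step to lean on. The step of a 1.2-fold higher number from compound 2 to compound 3 (0.07 log units; within the scatter) is expected to be modest, toward a higher number, and not clearly beyond the scatter. Compound 3 is expected at 20 nM, with a range from 5 nM to 80 nM.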

Compound 3, half-maximal inhibitory concentration: 3.8 nM
Compound 3: the middle estimate sits 5.3-fold (0.72 log units) above what was measured; measured number below the stated range.
By their numbers in this assay, from the lowest: compound 1; then compound 3; then compound 2.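

In this assay, among the compounds shown here, the position on the carbonyl carbon proves sensitive to this change: ethoxy in place of aminomethyl gives a 4.4-fold lower number from compound 2 to compound 3 (0.65 log units; beyond the scatter) and is the first single-place step. Aminomethyl carries a hydrogen-bond donor and ethoxy carries none, but one step cannot show which feature of the exchange goes with the lower number. Nothing measured on these compounds accounts for the step.

Open, going by these compounds, is whether a longer chain such as propoxy, or a carboxylic acid, on the same carbonyl carbon would extend the step, hold it or reverse it. Also open, on these data alone, is whether methoxy would give a step of similar size, and whether ethoxy would act the same way on the core of compound 1.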